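Swapping a Nitrile for an Isopropenyl Group

The source may hold more compounds than are shown below. What is called first, only, known or untested is meant among the compounds shown, and "the series" means these compounds.

Of the compounds shown here, three sharing one core have been measured in a functional assay on HL-60 cells (Homo sapiens) for inhibition, read by MTT assay, with a stated time of 72 h; on this read-out lower numbers stand for stronger inhibition and higher numbers for weaker inhibition. Compound 1, `Cc1nc(-c2ccc(F)cc2)c(C(=O)N2CCN(c3cccc(Cl)c3)CC2)o1`, gives 40.1 nM in this assay. Compound 2, `Cc1nc(-c2ccccc2)c(C(=O)N2CCN(c3cccc(C#N)c3)CC2)o1`, gives 39.6 nM in this assay. Compound 3, `COc1cccc(N2CCN(C(=O)c3oc(C)nc3-c3ccccc3F)CC2)c1`, gives 56.1 nM in this assay. Compound 2 has the lowest of the three numbers, yet compound 1 and compound 3 both sit within the usual scatter of it, so the three cannot be told apart on these data.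

The next compound, compound 4, `C=C(C)c1ccc(N2CCN(C(=O)c3oc(C)nc3-c3ccccc3)CC2)cc1`, has not yet been measured. It differs from compound 2 in one place: 4-(1-methylethenyl)phenyl in place of 3-cyanophenyl on an amine nitrogen in a ring. A group holding a nitrile thus gives way to a group with no hydrogen-bond acceptor at all, while the rest of the molecule is kept.

For the measured compounds named here, no pair of measured compounds shows this kind of exchange, so there is no measured step to lean on. Across the three measured compounds, different groups on the same amine nitrogen in a ring have left the numbers within the scatter of one another, which suggests that this change too will not move the number far. Compound 4 is therefore expected to give about 50 nM in this assay, most likely between 20 nM and 150 nM. The implied step, a 1.3-fold higher number from compound 2 to compound 4 (0.10 log units; within the scatter), is expected to stay within the usual scatter, with no clear direction.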

Compound 4, half-maximal inhibitory concentration: "not active" (no number reported)
No number was reported for compound 4, and the estimate cannot be compared.
By their numbers in this assay, from the lowest: compounds 2, 1 and 3 (each within the scatter of the next).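

In this assay, for the compounds shown here, compound 4 is reported as "not active", with no number, so no step from compound 2 to compound 4 can be read. Nothing measured here bears on why. The compounds shown leave open whether this result follows from the new group itself or from where it sits on the phenyl ring.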